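The source may report more compounds than this note shows. Statements on the series, on what has been measured and on what is new or still open speak of the compounds shown alone.

Working notes on the series. The shared core is that of compound 1 `CC(C)(C)CCNc1ncnc2c1ncn2[C@@H]1O[C@H](COS(N)(=O)=O)[C@@H](O)[C@H]1O`; in a functional assay on K562 cells (Homo sapiens) for antiproliferative activity, read by CellTiter-Glo, with a stated time of 72 h (a lower number here means that less compound is needed, a higher number that more compound is needed for the effect), compound 1 gives 929 nM. Compound 2 `CC(C)(C)CC(C)(C)Nc1ncnc2c1ncn2[C@@H]1O[C@H](COS(N)(=O)=O)[C@@H](O)[C@H]1O` gives in this assay only a limit, > 1000 nM, at the limit of > 1000 nM in this assay, at which 1 of the 3 values shown sits. Compound 3 `CCCCCC(C)Nc1ncnc2c1ncn2[C@@H]1O[C@H](COS(N)(=O)=O)[C@@H](O)[C@H]1O` gives 203 nM in this assay. Of the two numbers shown, compound 1 stands highest, the nearest being compound 3 by a 4.6-fold lower number from compound 1 to compound 3 (0.66 log units; beyond the scatter); the other value, for compound 2, is a limit.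

Compound 4 `NS(=O)(=O)OC[C@H]1O[C@@H](n2cnc3c(N4CCC5CCCCC5C4)ncnc32)[C@H](O)[C@@H]1O` differs from compound 1 on the aromatic carbon: a group of 10 heavy atoms (9 carbon, 1 nitrogen; one six-membered non-aromatic ring of carbon only, one six-membered non-aromatic ring with 1 hetero atom) in place of a group of 7 heavy atoms (6 carbon, 1 nitrogen; no ring), on an aromatic carbon

Two measured steps leave from compound 1. The exchange of 3,3-dimethylbutyl for 1,1,3,3-tetramethylbutyl gave an at least 1.0-fold higher number from compound 1 to compound 2 (0.03 log units; that floor lies within the scatter), a step that ends at the limit of compound 2, so its true size is open. The exchange for 1-methylhexyl gave a 4.6-fold lower number from compound 1 to compound 3 (0.66 log units; beyond the scatter). For the measured compounds named here, the change to compound 4 is larger than either, bringing in two rings and removing the hydrogen-bond donor, a direction no measured step covers, so the expectation rests mainly on the spread of the three values and leans toward the limit end. For compound 4 in this assay the expected value is 1300 nM, with a range from 300 nM to 6000 nM. The estimate amounts to an expected step of a 1.4-fold higher number from compound 1 to compound 4 (0.15 log units; within the scatter).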

Compound 4, half-maximal effective concentration: > 1000 nM
Compound 4: only a limit was reported (the forecaster's own chance of this, stated with the estimate: 45%); the middle value is on the limit's open side.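

Compound 4 gives only a limit in this assay, so a second compound in the series now sits at the same limit: the limit of > 1000 nM in this assay, at which 2 of the 4 values shown sit. On this aromatic carbon, the group with two six-membered non-aromatic rings and 0 hydrogen-bond donors gives an at least 4.9-fold higher number from compound 3 to compound 4 (0.69 log units; beyond the scatter), which shows that this replacement does not keep the level reached with the open-chain 1-methylhexyl group. For the compounds shown here, the other readable step, an at least 1.0-fold higher number from compound 1 to compound 4 (0.03 log units; that floor lies within the scatter), has a floor that lies within the scatter and so gives no order for that pair, and the step between the two limits cannot be read.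

Compound 4 brings in the rings and removes the hydrogen-bond donor in one change, so the compounds shown do not separate the two, and a single-ring piperidine or an N-methyl form of the 1-methylhexyl amine would bear on that question. Going by these compounds, how far the true values of compound 2 and compound 4 lie beyond their limits also stays open, as does whether any ring-bearing group on this carbon can reach the level of compound 3.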